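From Chloro to Methoxy at the Methylsulfonyl Site

The compounds below may be only part of what the source reports. "The series", "measured", "known", "first", "only" and "open" are said of these compounds alone.

Of the compounds shown here, three have been measured in an assay for binding affinity to Alpha-1D adrenergic receptor (Homo sapiens), read by radioligand binding; on this read-out higher numbers stand for weaker inhibition and lower numbers for stronger inhibition. Compound 1 `CS(=O)(=O)c1ccc(Cl)cc1NCC1=NCCN1` gives 2400 nM, the second highest of the three numbers; compound 3 `CS(=O)(=O)c1c(F)cccc1NCC1=NCCN1` gives 3470 nM, a number within the scatter of compound 1, while compound 2 `CSc1cc(F)ccc1NCC1=NCCN1` gives 5.01 nM, far below both. Compound 4 `COc1ccc(S(C)(=O)=O)c(NCC2=NCCN2)c1` has not yet been measured. It differs from compound 1 in one place: methoxy in place of chloro on an aromatic carbon. For the measured compounds named here, no measured pair shows this change, so its effect in this assay is unknown. Both compounds bearing a methylsulfonyl group sit at high numbers, compound 1 at 2400 nM and compound 3 at 3470 nM, and compound 4 is not expected to move far from them. Compound 4 is therefore estimated at 3000 nM, with a range from 800 nM to 12000 nM, a step of a 1.3-fold higher number from compound 1 to compound 4 (0.10 log units; within the scatter) expected to stay within the scatter.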

Compound 4, inhibition constant: 7590 nM
Beside the measured number, compound 4's estimate is 2.5-fold (0.40 log units) below it, and the stated range covers the measured number.
By their numbers in this assay, from the lowest: compound 2; then compounds 1 and 3 (each within the scatter of the next); then compound 4.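

Methoxy in place of chloro, para to a methylsulfonyl group, gives a 3.2-fold higher number from compound 1 to compound 4 (0.50 log units; beyond the scatter) in this assay, the first step that can be read at this position. The position therefore responds to this change, towards weaker inhibition, although the step is modest. Nothing measured here accounts for the step.

On these data alone, whether an amine or a carboxylic acid on this carbon would shift the number in the same direction remains open. So does whether a longer chain than methoxy would carry the step further.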